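From compound 3 to compound 4: an isomeric amine swap

A few compounds are considered here, and "the series" means these few. Any claim that something is new, unique, unknown or untested is made for them only; others in the source may bear on it.

In an ADME assay on HepG2 cells (Homo sapiens) for cytotoxicity, read by MTT assay, with a stated time of 72 h (on this read-out higher numbers stand for lower toxicity in this test and lower numbers for higher toxicity in this test), compound 1 `Cc1ccc(-c2cc3nc(N)[nH]c(=O)c3s2)cc1` gives "nd(insoluble)" (no result reported), so it offers no number. Compound 2 `CCCNc1nc2cc(-c3ccc(C)cc3)sc2c(=O)[nH]1` reads > 62500 nM, which is a limit of the assay and not a number. Going by the values given here, compound 3 `CCC(CC)Nc1nc2cc(-c3ccc(C)cc3)sc2c(=O)[nH]1` gives 101000 nM, the only actual number in the set.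

Compound 4 `CCCCN(C)c1nc2cc(-c3ccc(C)cc3)sc2c(=O)[nH]1` follows from compound 3 by butyl(methyl)amino in place of (pentan-3-yl)amino on an aromatic carbon; the two have the same atoms, joined differently.

Among the compounds with values here, the one measured step, a step that the limit leaves unreadable from compound 2 to compound 3, is the nearest guide, but it has no readable size and it is not the same change. The other evidence is the limit of > 62500 nM in this assay, at which 1 of the 3 values shown sits. Within the data shown here, no measured step therefore supports a shift in this assay in either direction. Compound 3 stands at 101000 nM. No step beyond the scatter is expected from it. The expected change is a 1.1-fold lower number from compound 3 to compound 4 (0.05 log units; within the scatter).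

For compound 4 the estimated value is 90000 nM, with an expected range from 35000 nM to 220000 nM.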

Compound 4, half-maximal cytotoxic concentration: 3000 nM
For compound 4 the middle estimate is 30-fold (1.48 log units) above the measured one, and the stated range ends above it.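

In this assay, the aromatic carbon between two ring nitrogen atoms responds strongly to how the same atoms are joined, as butyl(methyl)amino, with 0 hydrogen-bond donors, replaces (pentan-3-yl)amino, with 1: a 34-fold lower number from compound 3 to compound 4 (1.53 log units; beyond the scatter). Compound 2 carries a limit and not a number: the limit of > 62500 nM in this assay, at which 1 of the 4 values shown sits. Even against that limit the step from propylamino can be read, an at least 20-fold lower number from compound 2 to compound 4 (1.31 log units; beyond the scatter), so compound 4 stands apart from both other amines shown at this position.

Whether this drop belongs to the methyl on the nitrogen or to the butyl chain stays open, and butylamino, which would separate the two, lies outside the compounds shown. A ring amine such as morpholine also lies outside them, and the data give no cause for the step.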